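A Larger Aromatic Group on the Sulfur-Bound Chain

The source may hold more compounds than are shown below. What is called first, only, known or untested is meant among the compounds shown, and "the series" means these compounds.

This piece concerns two measured compounds and a third whose value is still to come. Compound 1 `Cc1ccc(CSc2nc3nc(C)cc(Nc4cc(-c5ccccc5)[nH]n4)n3n2)cc1` was tested in a functional assay on PC-9 cells (Homo sapiens) for inhibition, read by MTT assay, with a stated time of 72 h (on this read-out higher numbers stand for weaker inhibition and lower numbers for stronger inhibition), where compound 1 gives 7310 nM. Compound 2 `Cc1cc(Nc2cc(-c3cccs3)[nH]n2)n2nc(SCc3ccc(Br)cc3)nc2n1` differs from compound 1 at more than one place, and in this assay compound 2 gives 4890 nM; the two numbers lie within the usual scatter of repeated measurements, so nothing separates them on these data. Compound 1 thus stands alongside compound 2 rather than apart from it.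

Compound 3 `Cc1cc(Nc2cc(-c3ccccc3)[nH]n2)n2nc(SCc3cccc4ccccc34)nc2n1` carries a single change from compound 1: naphthalen-1-yl in place of 4-methylphenyl on a saturated chain carbon bound to a sulfur. Going by the values given here, no pair of measured compounds differs only at this place, so there is no measured step to lean on. With nothing beyond the two values shown, the expectation for compound 3 is a step in this assay of about a 1.3-fold lower number from compound 1 to compound 3 (0.12 log units; within the scatter), which is not expected to exceed the scatter in either direction. Compound 3 is accordingly estimated at 5500 nM, with a range from 1500 nM to 20000 nM.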

Compound 3, half-maximal inhibitory concentration: 3950 nM
Estimate against measurement, compound 3: 1.4-fold (0.14 log units) above; low and high end bracket the measured number.
By their numbers in this assay, from the lowest: compounds 3, 2 and 1 (each within the scatter of the next).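

Going by these compounds alone, replacing 4-methylphenyl with naphthalen-1-yl on a saturated chain carbon bound to a sulfur gives the first measured step at this place in this assay: a 1.9-fold lower number from compound 1 to compound 3 (0.27 log units; within the scatter). The entering group has 10 heavy atoms where the leaving group has 7, and it brings a second six-membered aromatic ring of carbon, yet the two compounds cannot be told apart on these numbers. This position therefore accepts a clearly larger all-carbon aromatic group with no change beyond the scatter, although nothing measured here speaks to the reason for this result.

This single step says nothing about how groups of a different kind would read in this assay at this place, such as a carboxylic acid, an amine or naphthalen-2-yl. Compound 2 differs from compound 1 at more than one place, so it cannot be used to separate the effect of this position from changes elsewhere on the molecule.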